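This account rests on a few compounds, and the source may have more. Where it says the series, first, only, none or still open, it means among the compounds named here.

Working notes on the series. Of the compounds shown here, three sharing one core have been measured in an assay on isolated protein for inhibition of serine/threonine-protein kinase PLK1 (Homo sapiens), read by Z'-LYTE; on this read-out higher numbers stand for weaker inhibition and lower numbers for stronger inhibition. Compound 1 `COc1cc(C(=O)NC2CCN(C)CC2)ccc1Nc1ncc2c(n1)N(C1CCCC1)[C@H](C)C(=O)N2C` gives 1.1 nM in this assay. Compound 2 `C[C@H]1C(=O)N(C)c2cnc(Nc3ccc(C(=O)NC4CCN(C)CC4)cc3OC3CCCC3)nc2N1C1CCCC1` gives 127 nM in this assay. Compound 3 `COC(=O)c1ccc(Nc2ncc3c(n2)N(C2CCCC2)[C@H](C)C(=O)N3C)c(OC2CCCC2)c1` gives 457 nM in this assay, which is the highest of the three numbers; the nearest value belongs to compound 2, and that gap lies beyond the scatter, while the value of compound 1 lies furthest away, also beyond the scatter. No two of these compounds differ in a single place, so no step between measured compounds can be stated.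

The step under consideration leads from compound 3 to compound 4 `C[C@@H]1C(=O)N(C)c2cnc(Nc3ccc(C(=O)NC4CCN(C)CC4)cc3OC3CCCC3)nc2N1C1CCCC1`. The change is (1-methylpiperidin-4-yl)amino in place of methoxy on a carbonyl carbon, so that methoxycarbonyl becomes (1-methylpiperidin-4-yl)carbamoyl. For the measured compounds named here, compounds 1 and 2 both carry the (1-methylpiperidin-4-yl)carbamoyl group and both give lower numbers than compound 3, which is the only reference for this change.

In this assay compound 4 is expected at 10 nM, with a range from 2 nM to 60 nM. The expected step from compound 3 to compound 4 is a 46-fold lower number from compound 3 to compound 4 (1.66 log units; beyond the scatter), a decrease well beyond the scatter, resting on the values of compound 1 1.1 nM and compound 2 127 nM.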

Compound 4, half-maximal inhibitory concentration: 40 nM
Compound 4: the middle estimate sits 4.0-fold (0.60 log units) below what was measured; the range from low to high includes it.
By their numbers in this assay, from the lowest: compound 1; then compound 4; then compound 2; then compound 3.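

The (1-methylpiperidin-4-yl)carbamoyl group can now be read on its own at this carbonyl carbon: in this assay, replacing methoxycarbonyl gives an 11-fold lower number from compound 3 to compound 4 (1.06 log units; beyond the scatter), a large step. Compound 4 also gives the oxygen substituent a clean comparison, since cyclopentyl in place of methyl on an oxygen on an aromatic ring appears as a 36-fold higher number from compound 1 to compound 4 (1.56 log units; beyond the scatter), again a large step, so the cyclopentyl ether costs much of what the carbamoyl group gains. The configuration at the saturated ring carbon also counts, though modestly, with R the lower of the two, and a 3.2-fold lower number from compound 2 to compound 4 (0.50 log units; beyond the scatter) can be assigned to that stereocentre alone because of this fact: the fact that compounds 2 and 4 differ only in the configuration as drawn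

Whether the lower number needs the 1-methylpiperidin-4-yl ring stays open, as the compounds shown offer no simpler amide such as a dimethylamide and no carboxylic acid at this carbonyl carbon. Also open, going by these compounds, are how ethyl or isopropyl on the oxygen would fall relative to methyl and cyclopentyl, and whether the configuration step keeps its size with methyl on that oxygen.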